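Amide series: chloro to cyano on the distal aryl

A few compounds are considered here, and "the series" means these few. Any claim that something is new, unique, unknown or untested is made for them only; others in the source may bear on it.

Measured compounds:
compound 1 `CC(C)(C)NC(=O)CCc1cccc2c1B(O)OC2`
compound 2 `C#Cc1ccc(NC(=O)CCc2cccc3c2B(O)OC3)cc1`
compound 3 `O=C(CCc1cccc2c1B(O)OC2)Nc1cccc(-c2ccc(Cl)cc2)c1`

In a functional assay on HCT-116 cells (Homo sapiens) for antiproliferative activity, read by MTT assay, with a stated time of 72 h (on this read-out lower numbers stand for stronger inhibition and higher numbers for weaker inhibition), compound 1 gives > 100000 nM, a limit of the assay rather than a number. Compound 1 thus sits at the limit of > 100000 nM in this assay, at which 1 of the 3 values shown sits. In this assay compound 2 gives 45000 nM. In this assay compound 3 gives 380 nM, the lowest of the two numbers measured, with compound 2 beyond the scatter above it. Compound 4 `N#Cc1ccc(-c2cccc(NC(=O)CCc3cccc4c3B(O)OC4)c2)cc1` is not yet measured. It differs from compound 3 by cyano in place of chloro on an aromatic carbon. Cyano in place of chloro on an aromatic carbon, para to a large group, leaves the rest of compound 3 unchanged; the numbers shown give no guide to how such a swap moves this read-out. Compound 4 is expected to stay near compound 3 in this assay, with a 1.6-fold higher number from compound 3 to compound 4 (0.20 log units; within the scatter) the estimated step, likely within or only slightly beyond the scatter. The estimate for compound 4 in this assay is 600 nM, between 150 nM and 2500 nM.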

Compound 4, half-maximal inhibitory concentration: 410 nM
For compound 4 the middle estimate is 1.5-fold (0.17 log units) above the measured one; measured number inside the range.
By their numbers in this assay, from the lowest: compounds 3 and 4 (each within the scatter of the next); then compound 2. At a limit, above all of these: compound 1.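

In this assay, cyano in place of chloro on an aromatic carbon, para to a large group, gives a 1.1-fold higher number from compound 3 to compound 4 (0.03 log units; within the scatter), so this place in the series accepts 4-cyanophenyl as well as 4-chlorophenyl without a shift beyond the scatter. For the compounds shown here, this is the first pair that differs in one place, and it shows that a triple bond and a hydrogen-bond acceptor can enter here while the two numbers remain within the scatter of each other. No measured property at hand bears on this result.

As far as these compounds go, whether other groups at this place, such as an amine or a carboxylic acid, would also fit remains open. Also open, from the compounds shown here alone, is how a longer chain in the amide linker would read out with either 4-chlorophenyl or 4-cyanophenyl in place.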